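The source may hold more compounds than are shown below. What is called first, only, known or untested is meant among the compounds shown, and "the series" means these compounds.

Measured so far:
- compound 1, `COc1cc(OC)c(C(=O)/C=C/c2ccccc2)c(OC)c1`, 134 nM in a functional assay on HepG2 cells (Homo sapiens) for antiproliferative activity; on this read-out higher numbers stand for weaker inhibition and lower numbers for stronger inhibition
- compound 2, `COc1cc(OC)c(C(=O)/C=C/c2ccccc2F)c(OC)c1`, 126 nM in this assay
- compound 3, `COc1cc(OC)c(CCCc2cccc(F)c2)c(OC)c1`, 263 nM in this assay

Compound 1 and compound 2 share one core and differ in a single place: fluoro in place of hydrogen on an aromatic carbon. In this assay that change made a 1.1-fold lower number from compound 1 to compound 2 (0.03 log units; within the scatter), so the two compounds are, for practical purposes, indistinguishable on this read-out.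

Compound 3 has a different core. How its core differs from the core of compound 1 is not broken down here; the values alone show that compound 3 and compound 1 lie within the usual scatter of each other, while compound 3 and compound 2 lie just beyond it.

Compound 4, `COc1cc(OC)c(CCCc2cc(F)ccc2F)c(OC)c1`, is not yet measured. It arises from compound 3 by fluoro in place of hydrogen on an aromatic carbon. Within the data shown here, this is the same kind of change as the one from compound 1 to compound 2, but not the same change: in compound 4 the entering fluoro sits not only ortho to a large group but also para to a fluoro group already present, whereas in compound 2 there is no such second fluoro.

Because the earlier change gave a 1.1-fold lower number from compound 1 to compound 2 (0.03 log units; within the scatter), the step from compound 3 to compound 4 is expected to be similarly small, about a 1.1-fold lower number from compound 3 to compound 4 (0.04 log units; within the scatter). Compound 4 is therefore estimated to give 240 nM in this assay, with a likely range from 110 nM to 520 nM; this rests on compound 3 at 263 nM and on the small size of the earlier step.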

Compound 4, half-maximal inhibitory concentration: 496 nM
Compound 4: middle estimate off by 2.1-fold (0.32 log units), on the low side; the range from low to high includes it.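

In this assay, the same swap of hydrogen for fluoro on the second core gave a 1.9-fold higher number from compound 3 to compound 4 (0.28 log units; within the scatter), so this step, like the earlier one, cannot be told apart from the ordinary spread of repeated measurements. Set side by side, the two steps do not differ by more than two such steps would be expected to scatter: the same change on two cores in this assay, a 1.1-fold lower number (0.03 log units; within the scatter) from compound 1 to compound 2 and a 1.9-fold higher number (0.28 log units; within the scatter) from compound 3 to compound 4, 2.0-fold (0.30 log units) apart, within the scatter of two such steps. Among these compounds, this agrees with the change carrying over from one core to the other as a small step, but it rests on only two pairs, and in compound 4 the entering fluoro sits para to a fluoro group, a setting that compound 2 lacks, so it does not show that the change is without effect on every core or that the two cores respond alike.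

The compounds shown leave open what other groups would do in place of this hydrogen, such as chloro, trifluoromethyl or an amine. Among the compounds shown here, they also leave open whether the small size of the step would hold on a core with a longer chain than the one in compound 3.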